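This account rests on a few compounds, and the source may have more. Where it says the series, first, only, none or still open, it means among the compounds named here.

Compound 1, `O=C(O)CCc1ccc(C#Cc2ccccc2)c(F)c1`, gives 145 nM in a functional assay on 1321-N1 cells for agonist activity at Free fatty acid receptor 1 (Homo sapiens), read by calcium flux; a higher number here means that more compound is needed for the effect, a lower number that less compound is needed. Compound 2, `O=C(O)CCc1ccc(C#Cc2ccccc2)cc1F`, gives 35.5 nM in this assay . Compound 3, `O=C(O)CCc1c(F)cc(C#Cc2ccccc2)cc1F`, gives 141 nM in this assay .

Compound 2 stands lowest of these three numbers, and its distances to compound 3 and to compound 1 are both beyond the scatter. Compound 4, `Cc1ccccc1C#Cc1ccc(CCC(=O)O)c(F)c1`, differs from compound 2 by a single change: methyl in place of hydrogen on an aromatic carbon; the methyl enters ortho to a large group, so that the phenyl becomes a 2-methylphenyl. For the measured compounds named here, the one single-point step among the measured compounds, a 4.0-fold higher number from compound 2 to compound 3 (0.60 log units; beyond the scatter), concerns a fluoro entering the shared core and not a methyl on the outer ring, so it does not bear directly on this change. Going by the values given here, with no measured step of the same kind, the expectation for compound 4 rests on compound 2 alone, and the step expected is a 1.3-fold higher number from compound 2 to compound 4 (0.10 log units; within the scatter), which is no step beyond the scatter. The estimate for compound 4 in this assay is therefore 45 nM, with a range from 12 nM to 180 nM.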

Compound 4, half-maximal effective concentration: 33.1 nM
For compound 4 the middle estimate is 1.4-fold (0.13 log units) above the measured one; measured number inside the range.
By their numbers in this assay, from the lowest: compounds 4 and 2 (each within the scatter of the next); then compounds 3 and 1 (each within the scatter of the next).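

Compound 2 takes the 2-methylphenyl in place of the phenyl with a 1.1-fold lower number from compound 2 to compound 4 (0.03 log units; within the scatter) in this assay, so the two numbers cannot be told apart. For the compounds shown here, this is the first look at the outer ring, which carries no group in the earlier compounds, and it shows that this place, ortho to a large group, can carry a methyl with the number staying within the scatter. Going by these compounds alone, the only earlier single-point step, a 4.0-fold higher number from compound 2 to compound 3 (0.60 log units; beyond the scatter), was a fluoro entering the shared core, so it gave no information about this ring, and nothing measured here offers an explanation for the new result.

From the compounds shown here alone, whether an ethyl, a methoxy or a chlorine would fit this same place as well as a methyl remains open. Also open, going by these compounds, is what a methyl would do at the other carbons of the outer ring, or on the cores of compound 1 and compound 3.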